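The source may hold more compounds than are shown below. What is called first, only, known or untested is meant among the compounds shown, and "the series" means these compounds.

Measured so far:
- compound 1 `COc1ccc(S(=O)(=O)c2cnc3ccc(C)cc3c2N2CCC(C)CC2)cc1`: 62%
- compound 2 `COc1ccc(S(=O)(=O)c2cnc3ccc(F)cc3c2N2CCC(C)CC2)cc1`: 85%

Both readings come from an assay on isolated protein for displacement of a labelled ligand from metabotropic glutamate receptor 5 (Homo sapiens), with a stated time of 60 min, tested at 1 uM; on this read-out lower numbers stand for less inhibition and higher numbers for more inhibition at the one concentration tested (going by the name of the read-out). For the measured compounds named here, compound 2 gives the higher of the two numbers, and the only measured step, a number 23 percentage points higher from compound 1 to compound 2 (beyond the scatter), is the one that separates it from compound 1.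

Compound 3 `CC1CCN(c2c(S(=O)(=O)c3cccc(F)c3)cnc3ccc(F)cc23)CC1` is not yet measured. It differs from compound 2 at the sulfonyl sulfur: 3-fluorophenyl in place of 4-methoxyphenyl on a sulfonyl sulfur

Going by the values given here, no measured step touches the group on the sulfonyl sulfur; the single step recorded concerns the fluoro in place of methyl on an aromatic carbon of the shared core, which is unchanged between compound 2 and compound 3. There is therefore no basis from the data for a direction, and the expectation is that a number 10 percentage points lower from compound 2 to compound 3 (within the scatter) stays within the scatter, with a wide range to reflect the absence of any comparable step. Compound 3 is estimated at 75% in this assay, between 45% and 95%.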

Compound 3, a percentage reported as inhibition, at one concentration (the size of the read-out at that concentration, not a potency): 76%
For compound 3 the middle estimate is 1 percentage points below the measured one; the range from low to high includes it.
By their numbers in this assay, from the lowest: compound 1; then compounds 3 and 2 (each within the scatter of the next).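

In this assay, for the compounds shown here, the first step at this position, 3-fluorophenyl in place of 4-methoxyphenyl on a sulfonyl sulfur, gives a number 9 percentage points lower from compound 2 to compound 3 (within the scatter). This single exchange therefore does not separate the two compounds on this read-out, although the two groups differ in their ring substituent. Going by these compounds alone, the only step beyond the scatter remains the one on the aromatic carbon of the shared core, a number 23 percentage points higher from compound 1 to compound 2 (beyond the scatter), and nothing measured bears on the reason for the new result.

Still open, from the compounds shown here alone, is whether the reading holds when the group on the sulfonyl sulfur is a cyclohexyl ring or a phenyl ring carrying a carboxylic acid. A reading at one concentration gives no potency, so any difference in potency between compound 2 and compound 3 also remains unresolved.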